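Swapping an ester-like side chain for a basic ring

A few compounds are considered here, and "the series" means these few. Any claim that something is new, unique, unknown or untested is made for them only; others in the source may bear on it.

Compounds measured in an assay for inhibition of serine/threonine-protein kinase Sgk1 (Homo sapiens), with stated times of 30 min and 60 min, in the presence of a further agent that is not named here; on this read-out higher numbers stand for weaker inhibition and lower numbers for stronger inhibition:
- compound 1, `O=C(NC1CCN(C2CC2)C1)c1cc(-c2ccc(NS(=O)(=O)c3cccc(Cl)c3Cl)cc2)nc2[nH]ncc12`, gives 6 nM
- compound 2, `CCNC(=O)c1cc(-c2ccc(NS(=O)(=O)c3cccc(Cl)c3Cl)cc2)nc2[nH]ncc12`, gives 6 nM
- compound 3, `Cc1n[nH]c2nc(-c3ccc(NS(=O)(=O)c4cc(Cl)ccc4F)cc3)nc(OCCC(=O)N(C)C)c12`, gives 15 nM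

Compound 3 stands highest of the three numbers on this assay; compound 1 and compound 2 both lie below it by the same margin, and that margin is beyond the scatter. Compound 4, `CCN1CCCC(Oc2nc(-c3ccc(NS(=O)(=O)c4cc(Cl)ccc4F)cc3)nc3[nH]nc(C)c23)C1`, has not yet been measured. It differs from compound 3 in one place: 1-ethylpiperidin-3-yl in place of 2-(dimethylcarbamoyl)ethyl on an oxygen on an aromatic ring.

Within the data shown here, one measured step bears on this, though only loosely: no change at the digits printed from compound 1 to compound 2 (within the scatter). There, on a different core and on an amide-type nitrogen rather than an oxygen, a small alkyl and a saturated nitrogen-containing ring gave the same number. Nothing measured here speaks to the oxygen-linked position of compound 3 itself. The nearest evidence therefore points to a step of no more than the scatter, with no clear direction.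

Compound 4 is expected to give about 12 nM on this assay, between 4 nM and 40 nM, a step of a 1.3-fold lower number from compound 3 to compound 4 (0.10 log units; within the scatter) from compound 3.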

Compound 4, half-maximal inhibitory concentration: 6 nM
Beside the measured number, compound 4's estimate is 2.0-fold (0.30 log units) above it; low and high end bracket the measured number.
By their numbers in this assay, from the lowest: compounds 1, 2 and 4 (each within the scatter of the next); then compound 3.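

In this assay, the group on the oxygen of this core does affect the read-out: exchanging 2-(dimethylcarbamoyl)ethyl for 1-ethylpiperidin-3-yl gives a 2.5-fold lower number from compound 3 to compound 4 (0.40 log units; beyond the scatter), a modest step but one beyond the scatter. Among these compounds, the only earlier step, on an amide-type nitrogen of a different core, gave no change at the digits printed from compound 1 to compound 2 (within the scatter), so it could not show that a saturated nitrogen-containing ring can shift the number at all. Nothing available explains why this exchange lowers the number.

The compounds shown leave open whether the step belongs to the ring or to the ethyl on its nitrogen, which a piperidin-3-yl carrying hydrogen or methyl there would help to separate. Also open, from the compounds shown here alone, is whether an open-chain amine such as 2-(dimethylamino)ethyl on the same oxygen would behave like the ring of compound 4.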